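Working notes: 3-aminophenyl in place of 3,5-dimethoxyphenyl

This account rests on a few compounds, and the source may have more. Where it says the series, first, only, none or still open, it means among the compounds named here.

Measured in a functional assay on A549 cells (Homo sapiens) for cytotoxicity, read by MTT assay, with a stated time of 72 h; a higher number here means a weaker inhibitor, a lower number a stronger inhibitor:
- Compound 1 `Cc1ccc(S(=O)(=O)c2nc3ccccc3nc2Nc2cccc(N)c2)cc1` gives 1950 nM
- Compound 2 `COc1ccc(S(=O)(=O)c2nc3ccccc3nc2Nc2cc(OC)cc(OC)c2)cc1` gives 12700 nM

In this assay, compound 2 has the higher of the two numbers at 12700 nM, which makes it the weaker inhibitor, and its gap to compound 1 lies beyond the scatter.

Compound 3 `COc1ccc(S(=O)(=O)c2nc3ccccc3nc2Nc2cccc(N)c2)cc1` has not yet been measured. It differs from compound 2 by 3-aminophenyl in place of 3,5-dimethoxyphenyl on a nitrogen on an aromatic ring. Going by the values given here, no measured pair isolates this change. Among the compounds with values here, the only guide is compound 1, which also carries 3-aminophenyl and gives 1950 nM.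

On that basis, the expected step of a 5.1-fold lower number from compound 2 to compound 3 (0.71 log units; beyond the scatter) runs towards a lower number and beyond the scatter, though with wide uncertainty. For compound 3 the estimated value is 2500 nM, with an expected range of 900 nM to 7000 nM.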

Compound 3, half-maximal inhibitory concentration: 340 nM
Beside the measured number, compound 3's estimate is 7.4-fold (0.87 log units) above it; measured number outside the range, below it.
By their numbers in this assay, from the lowest: compound 3; then compound 1; then compound 2.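

In this assay the change from 3,5-dimethoxyphenyl to 3-aminophenyl on a nitrogen on an aromatic ring now has a matched pair, which gives a 37-fold lower number from compound 2 to compound 3 (1.57 log units; beyond the scatter) and marks this position as a large source of change in the series. The other varied place also matters: methoxy in place of methyl on an aromatic carbon gives a 5.7-fold lower number from compound 1 to compound 3 (0.76 log units; beyond the scatter) as a modest step that still lies beyond the scatter. No accompanying data account for either step.

The step at the nitrogen removes both methoxy groups and adds the amine in one change, so a plain phenyl there would be needed to separate the two. At the other place, only methyl and methoxy are compared, leaving ethoxy or chlorine untested in this set.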